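Three Analogues at the Assay Limit, a Fourth Awaits

The source may report more compounds than this note shows. Statements on the series, on what has been measured and on what is new or still open speak of the compounds shown alone.

Compound 1 `O=C(/C=C\Nc1cnc2ccccc2c1)c1nc(-c2ccc(C(F)(F)F)cc2)n2ccccc12`: in a functional assay on MDA-MB-231 cells (Homo sapiens) for cytotoxicity, read by MTT assay, with a stated time of 48 h (a higher number here means a weaker inhibitor, a lower number a stronger inhibitor), compound 1 reaches only the limit > 30000 nM.
Compound 2 `COc1ccc(-c2nc(C(=O)/C=C\Nc3ccc(F)cc3)c3ccccn23)cc1`: in this assay compound 2 likewise stops at the limit > 30000 nM.
Compound 3 `Cc1cc2cc(N/C=C\C(=O)c3nc(-c4ccc(F)cc4)n4ccccc34)ccc2[nH]1`: in this assay compound 3 also gives no number, only the limit > 30000 nM.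

Among the compounds with values here, compound 3 therefore stands level with its two companions: all three sit at the same ceiling, as the limit of > 30000 nM in this assay, at which 3 of the 3 values shown sit, records, so no order among them can be read, and no step between measured compounds is available to lean on. Compound 4 `O=C(/C=C\Nc1ccc(F)cc1)c1nc(-c2ccc(F)cc2)n2ccccc12` differs from compound 3 in one place only: 4-fluorophenyl in place of 2-methyl-1H-indol-5-yl on an amine nitrogen. Compound 2, which already carries a 4-fluorophenyl on its amine nitrogen, sits at the limit as well. The step from compound 3 to compound 4 in this assay is expected to be none beyond the usual scatter, that is a step that the limit leaves unreadable from compound 3 to compound 4, most probably ending once more at a limit rather than a number. Compound 4 is thus estimated at 40000 nM, with a range from 15000 nM to 150000 nM.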

Compound 4, half-maximal inhibitory concentration: 25100 nM
The estimate for compound 4 lay 1.6-fold (0.20 log units) above the measured number, and the stated range covers the measured number.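

Within the data shown here, compound 4 is the only one of the four compounds to give a number rather than a limit in this assay, so this position can now yield a readable value. Putting 4-fluorophenyl in place of 2-methyl-1H-indol-5-yl on the amine nitrogen gives an at least 1.1-fold lower number from compound 3 to compound 4 (0.07 log units; that floor lies within the scatter), while fluoro in place of methoxy on an aromatic carbon gives an at least 1.1-fold lower number from compound 2 to compound 4 (0.07 log units; that floor lies within the scatter). Each step has a limit at its starting end, so each shows only a smallest possible size, and neither floor is beyond the scatter: the limit of > 30000 nM in this assay, at which 3 of the 4 values shown sit.

Still open, on these data alone, is how a cyclohexyl group or a piperidine ring would fare on the amine nitrogen in place of 4-fluorophenyl. Also open, as far as these compounds go, is whether any change can move the number clearly beyond the scatter.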